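Methoxy to ethoxy: is a shift expected?

The source may report more compounds than this note shows. Statements on the series, on what has been measured and on what is new or still open speak of the compounds shown alone.

Compound 1 `C=C(Br)C(=O)Nc1ccc(/C=C/C(=O)c2ccc(Br)cc2)cc1` gives 620 nM in a functional assay on L1210 cells (Mus musculus) for antiproliferative activity, with a stated time of 48 h; on this read-out higher numbers stand for weaker inhibition and lower numbers for stronger inhibition
Compound 2 `C=C(Br)C(=O)Nc1ccc(/C=C/C(=O)c2ccc(OC)cc2)cc1` gives 980 nM in this assay

Within the data shown here, with only two compounds measured, compound 2 stands within the scatter of compound 1, so neither can be ranked above the other. Compound 3 `C=C(Br)C(=O)Nc1ccc(/C=C/C(=O)c2ccc(OCC)cc2)cc1` differs from compound 2 in one place (methyl in place of hydrogen on a saturated chain carbon bound to an oxygen on an aromatic ring), with methyl in place of hydrogen on a saturated chain carbon bound to an oxygen on an aromatic ring, turning methoxy into ethoxy.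

Among the measured compounds shown here, only one measured step bears on this: bromo replaced by methoxy on an aromatic carbon (a 1.6-fold higher number from compound 1 to compound 2 (0.20 log units; within the scatter)). Even that exchange of two different groups stayed within the scatter, although no measurement yet tests a longer chain on the oxygen. No shift in either direction beyond the scatter is therefore expected (a 1.2-fold lower number from compound 2 to compound 3 (0.06 log units; within the scatter)). Compound 3 is expected at 850 nM within an estimated range of 350 nM to 2000 nM in this assay for now.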

Compound 3, half-maximal inhibitory concentration: 240 nM
For compound 3 the middle estimate is 3.5-fold (0.55 log units) above the measured one; measured number outside the range, below it.
By their numbers in this assay, from the lowest: compound 3; then compounds 1 and 2 (each within the scatter of the next).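

Adding one methyl to the methoxy group, which turns it into ethoxy, gives a 4.1-fold lower number from compound 2 to compound 3 (0.61 log units; beyond the scatter) in this assay, so this position responds to a single added carbon, a change far smaller than the bromo-to-methoxy exchange that stayed within the scatter. Going from bromo to ethoxy gives a 2.6-fold lower number from compound 1 to compound 3 (0.41 log units; beyond the scatter) as well, which sets ethoxy apart from both other groups beyond the scatter. Nothing shown here explains why the extra methyl has this effect.

Going by these compounds, whether a longer chain on the oxygen, such as propoxy or butoxy, would lower the number further or raise it again remains open. On these data alone, how a hydroxy group or an amine would behave on this aromatic carbon is also open.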